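Varying the aryl group on a shared chromone core

A few compounds are considered here, and "the series" means these few. Any claim that something is new, unique, unknown or untested is made for them only; others in the source may bear on it.

Compound 1 `CCC1=C(O)c2c(oc(-c3ccc(O)cc3)cc2=O)C(CC)(CC)C1=O`: 20.6 uM
Compound 2 `CCC1=C(O)c2c(oc(-c3cccc(OC(F)(F)F)c3)cc2=O)C(CC)(CC)C1=O`: 9.95 uM
Compound 3 `CCC1=C(O)c2c(oc(-c3cccc(F)c3)cc2=O)C(CC)(CC)C1=O`: 3.09 uM

Three compounds share one core and differ only in the aryl group. In a functional assay on KBVIN cells (Homo sapiens) for antiproliferative activity, read by sulforhodamine B assay, with a stated time of 3 days (a higher number here means that more compound is needed for the effect, a lower number that less compound is needed), compound 1 gives 20.6 uM, compound 2 gives 9.95 uM and compound 3 gives 3.09 uM. Compound 3 therefore stands lowest of the three numbers, with compound 2 nearest and compound 1 furthest from it.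

Compound 4 `CCC1=C(O)c2c(oc(-c3ccc(OC)c(Cl)c3)cc2=O)C(CC)(CC)C1=O` has not yet been measured in this assay. It differs from compound 3 in one place: 3-chloro-4-methoxyphenyl in place of 3-fluorophenyl on an aromatic carbon.

For the measured compounds named here, two measured steps bear on this change. Going from a 4-hydroxyphenyl group to the 3-fluorophenyl group gave a 6.7-fold lower number from compound 1 to compound 3 (0.82 log units; beyond the scatter), and going from a trifluoromethoxy group to fluoro gave a 3.2-fold lower number from compound 2 to compound 3 (0.51 log units; beyond the scatter). Both steps point the same way: the 3-fluorophenyl group of compound 3 gave the lowest number, and both larger or oxygen-bearing aryl groups gave higher numbers. Compound 4 brings back an oxygen-bearing aryl group with more heavy atoms, so a modest step upward is expected, of the order of a 2.6-fold higher number from compound 3 to compound 4 (0.41 log units; beyond the scatter). For compound 4 the expected value in this assay is 8 uM, within a range of 3 uM to 20 uM.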

Compound 4, concentration for half-maximal effect: 1.37 uM
Compound 4: the middle estimate sits 5.8-fold (0.77 log units) above what was measured; measured number outside the range, below it.
By their numbers in this assay, from the lowest: compound 4; then compound 3; then compound 2; then compound 1.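

In this assay, the 3-chloro-4-methoxyphenyl group in place of 3-fluorophenyl gives a 2.3-fold lower number from compound 3 to compound 4 (0.35 log units; beyond the scatter), so compound 4 goes against the pattern of the first three compounds, in which the 3-fluorophenyl group gave the lowest number and both oxygen-bearing aryl groups gave higher ones. An oxygen-bearing aryl group with more heavy atoms is therefore compatible with a lower number at this position on the shared core, and the identity of the aryl group matters more than the mere presence of oxygen: replacing 4-hydroxyphenyl with 3-chloro-4-methoxyphenyl gives a 15-fold lower number from compound 1 to compound 4 (1.18 log units; beyond the scatter), the largest step among these compounds. Nothing measured here explains why the number falls with this change.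

Compound 4 brings in chloro and methoxy together, so the compounds shown do not tell how much of the step belongs to each, which a phenyl group carrying only chloro or only methoxy could separate. They also leave open how this position would respond to an amine, a carboxylic acid or a longer alkoxy chain on the aryl ring.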